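This account rests on a few compounds, and the source may have more. Where it says the series, first, only, none or still open, it means among the compounds named here.

In an ADME assay on liver for metabolic stability, with Liver microsome (Canis lupus familiaris) as the target, read by HPLC, using microsomes (on this read-out higher numbers stand for a longer-lived compound and lower numbers for a shorter-lived compound), compound 2 `COCCOc1cc2c(-n3nc(-c4ccccn4)nc3N)ncnc2cc1OC` reads > 4 h, a limit and not a number. Compound 1 `COCCOc1cc2ncnc(-n3nc(-c4ccccn4)nc3N)c2cc1OCCOC` reads > 4 h, also a limit. Both compounds sit at the limit of > 4 h in this assay, at which 2 of the 2 values shown sit. Among the measured compounds shown here, the only measured step, a step that the two limits leave unreadable from compound 1 to compound 2, therefore gives no size to carry forward. Compound 3 `COc1cc2ncnc(-n3nc(-c4ccccn4)nc3N)c2cc1OCCCNC(=O)OC(C)C` differs from compound 2 by ((isopropoxycarbonyl)amino)methyl in place of methoxy on a saturated chain carbon, two bonds along the chain from an oxygen on an aromatic ring, with ((isopropoxycarbonyl)amino)methyl in place of methoxy on a saturated chain carbon, two bonds along the chain from an oxygen on an aromatic ring. For the measured compounds named here, no measured step covers this change, so the expectation is loose: an at least 1.3-fold lower number from compound 2 to compound 3 (0.12 log units; that floor lies within the scatter), tentatively toward a shorter-lived compound. For compound 3 the estimated half-life is 3 h, with an expected range of 1 h to 6 h.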

Compound 3, half-life: > 4 h
Compound 3 was reported as a limit (the forecaster's own chance of this, stated with the estimate: 45%); at least 1.3-fold (0.12 log units) between middle value and limit.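

No new step can be read between compound 2 and compound 3, since both stand at a limit: the limit of > 4 h in this assay, at which 3 of the 3 values shown sit.
The compounds shown leave open how long any of the three actually lasts, and whether either change alters the half-life at all.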